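Methyl replacing hydroxy on the aryl ring of compound 3

This account rests on a few compounds, and the source may have more. Where it says the series, first, only, none or still open, it means among the compounds named here.

Three measured compounds share one core and differ only in the group on the pendant benzene ring. Compound 1 `Cn1c(-c2ccc(F)cc2)nc2c(NC3CCCC3)ncnc21` gives 6.2 nM in an assay on CHO cells for displacement of a labelled ligand from adenosine receptor A1 (Homo sapiens), read by scintillation counting, with a stated time of 3 h; a higher number here means a weaker inhibitor, a lower number a stronger inhibitor. Compound 2 `Cn1c(-c2ccc(C(=O)O)cc2)nc2c(NC3CCCC3)ncnc21` gives 54000 nM, and compound 3 `Cn1c(-c2ccc(O)cc2)nc2c(NC3CCCC3)ncnc21` gives 17 nM. Compound 3 thus holds the second highest number of the three: it stands a 2.7-fold higher number from compound 1 to compound 3 (0.44 log units; beyond the scatter) away from compound 1, while the change a 3200-fold lower number from compound 2 to compound 3 (3.50 log units; beyond the scatter) separates it from compound 2 by a wide margin.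

The next compound, compound 4 `Cc1ccc(-c2nc3c(NC4CCCC4)ncnc3n2C)cc1`, is reached from compound 3 by methyl in place of hydroxy on an aromatic carbon. Among the measured compounds shown here, no measured step exchanges hydroxy for methyl directly. For the measured compounds named here, the steps that bear on it are a 2.7-fold higher number from compound 1 to compound 3 (0.44 log units; beyond the scatter), a modest shift between two small neutral groups lacking a carboxy, and the large ones an 8700-fold higher number from compound 1 to compound 2 (3.94 log units; beyond the scatter) and a 3200-fold lower number from compound 2 to compound 3 (3.50 log units; beyond the scatter). Both of the large steps are the ones in which a carboxy enters or leaves. Methyl, like fluoro, carries no hydrogen-bond donor or acceptor and no charge, so compound 4 is expected to land near compound 1 rather than compound 2, giving a step of a 1.7-fold lower number from compound 3 to compound 4 (0.23 log units; within the scatter) that is modest and toward a lower number, possibly within the scatter. The estimate for compound 4 in this assay is 10 nM, with a range from 3 nM to 35 nM.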

Compound 4, inhibition constant: 8 nM
The estimate for compound 4 lay 1.3-fold (0.10 log units) above the measured number; the measured number falls inside the stated range.
By their numbers in this assay, from the lowest: compounds 1 and 4 (each within the scatter of the next); then compound 3; then compound 2.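

Hydroxy is not required at this place, on the aromatic carbon para to a large group: in this assay methyl, with 0 hydrogen-bond donors and 0 hydrogen-bond acceptors, gives a modest step (a 2.1-fold lower number from compound 3 to compound 4 (0.33 log units; beyond the scatter)), and this is the first exchange at this place of hydroxy for a group without either feature. Methyl and fluoro cannot be told apart here (a 1.3-fold higher number from compound 1 to compound 4 (0.11 log units; within the scatter)), whereas the step from carboxy is large (a 6800-fold lower number from compound 2 to compound 4 (3.83 log units; beyond the scatter)), so a carbon attached to the ring does not by itself go with the very high number of compound 2, and the series so far separates carboxy from the other three groups. No supporting data are available to explain any of these differences.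

The compounds shown leave open whether the large step is specific to a carboxylic acid or also appears with an amine, a primary amide or a methyl ester at this place. They also leave open whether a longer chain such as ethyl or propyl, or a methoxy group, stays with methyl and fluoro on the shared core.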